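Aryl swap on the ring nitrogen: compound 4 from compound 3

The compounds below may be only part of what the source reports. "The series", "measured", "known", "first", "only" and "open" are said of these compounds alone.

Compound 3 `CCc1cccc(CC)c1-n1nncc1CN1C(=O)C2(C(C#N)=C(N)Oc3c(N)cc4nc5ccccc5nc4c32)c2ccccc21` stands at a limit: in an ADME assay on HUVEC cells (Homo sapiens) for antiproliferative activity, read by MTT assay, with a stated time of 48 h (a lower number here means a stronger inhibitor, a higher number a weaker inhibitor), compound 3 gives > 50000 nM, which is a limit of the assay and not a number. Compound 1 `N#CC1=C(N)Oc2c(N)cc3nc4ccccc4nc3c2C12C(=O)N(Cc1cnnn1-c1cccc(Br)c1)c1ccccc12` likewise gives a limit in this assay, where compound 1 gives > 50000 nM. Compound 2 `N#CC1=C(N)Oc2c(N)cc3nc4ccccc4nc3c2C12C(=O)N(Cc1cnnn1-c1ccccc1Br)c1ccccc12` gives 34200 nM in this assay. The measured steps that end on compound 3 are a step that the two limits leave unreadable from compound 1 to compound 3 and an at least 1.4-fold higher number from compound 2 to compound 3 (0.16 log units; that floor lies within the scatter); both run into (the limit of > 50000 nM in this assay, at which 2 of the 3 values shown sit), so neither shows how far past it compound 3 lies. Compound 4 `Cc1cc(C)c(-n2nncc2CN2C(=O)C3(C(C#N)=C(N)Oc4c(N)cc5nc6ccccc6nc5c43)c3ccccc32)c(C)c1` differs from compound 3 in one place only: 2,4,6-trimethylphenyl in place of 2,6-diethylphenyl on an aromatic nitrogen. Among the measured compounds shown here, no measured step changes the group on that aromatic nitrogen between two numbered values, so the expectation rests on compound 3 sitting at the limit of > 50000 nM in this assay, at which 2 of the 3 values shown sit, and on the small size of the change. Compound 4 is expected to remain near the limit, with an estimated step that the limit leaves unreadable from compound 3 to compound 4 that amounts to no step beyond the scatter. The estimate for compound 4 in this assay is 60000 nM, within a range from 25000 nM to 150000 nM.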

Compound 4, half-maximal inhibitory concentration: > 50000 nM
Compound 4: a limit, no number; the forecaster's own chance of this, stated with the estimate: 70%; the middle value is on the limit's open side.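

In this assay compound 4 gives > 50000 nM, which is a limit of the assay and not a number. Among the compounds shown here, the only readable new step is an at least 1.4-fold higher number from compound 2 to compound 4 (0.16 log units; that floor lies within the scatter), and the steps from compound 1 and from compound 3 to compound 4 cannot be read. On this aromatic nitrogen, 2,4,6-trimethylphenyl now joins 2,6-diethylphenyl and 3-bromophenyl at the limit, leaving the 2-bromophenyl of compound 2 as the only aryl group with a number: the limit of > 50000 nM in this assay, at which 3 of the 4 values shown sit.

The compounds shown leave open whether a phenyl bearing an amine or a carboxylic acid on this nitrogen would give a number clear of the limit. They also leave open how far past the limit compound 1, compound 3 and compound 4 lie, and whether any order exists among them.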